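This account rests on a few compounds, and the source may have more. Where it says the series, first, only, none or still open, it means among the compounds named here.

Measured in a functional assay on A-431 cells (Homo sapiens) for inhibition, with a stated time of 72 h; on this read-out lower numbers stand for stronger inhibition and higher numbers for weaker inhibition:

- compound 1 `COCc1cc(CN2CCCC2)c(O)c2ncccc12` gives 52500 nM
- compound 2 `CCOCc1cc(CN2CCCC2)c(O)c2ncccc12` gives 33100 nM

On these numbers compound 2 cannot be separated from compound 1. Within the data shown here, the only measured step, a 1.6-fold lower number from compound 1 to compound 2 (0.20 log units; within the scatter), lies within the scatter, so the two values set no order.

Compared with compound 2, compound 3 `CCOCc1cc(CN2CCC(C)CC2)c(O)c2ncccc12` carries 4-methylpiperidin-1-yl in place of pyrrolidin-1-yl on a saturated chain carbon bound to an aromatic carbon. Among the measured compounds shown here, the one measured step does not bear directly on this exchange. For the measured compounds named here, it concerns a different place, a saturated chain carbon bound to an oxygen, and no measured pair alters the pyrrolidin-1-yl group. The data therefore give no ground for expecting a shift beyond the scatter in this assay, and they leave the direction open, so the range has to stay wide. The estimated change is only a 1.3-fold lower number from compound 2 to compound 3 (0.12 log units; within the scatter). Compound 3 is expected at about 25000 nM, with an estimated range from 9000 nM to 65000 nM.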

Compound 3, half-maximal inhibitory concentration: 11000 nM
Estimate against measurement, compound 3: 2.3-fold (0.36 log units) above; measured number inside the range.
By their numbers in this assay, from the lowest: compound 3; then compounds 2 and 1 (each within the scatter of the next).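

Among these compounds, the exchange of pyrrolidin-1-yl for 4-methylpiperidin-1-yl on a saturated chain carbon bound to an aromatic carbon gives the first step in this assay that lies beyond the scatter, a 3.0-fold lower number from compound 2 to compound 3 (0.48 log units; beyond the scatter), and the direction it takes is toward stronger inhibition. This shows that the amine ring at this position can move the read-out, which the earlier step at the saturated chain carbon bound to an oxygen, lying within the scatter, could not show for its own position, although the effect here is modest and compound 3 still stands at 11000 nM in this micromolar-range series. Nothing available here bears on why the number falls with this exchange.

The compounds shown leave open whether the step follows from the six-membered ring or from its methyl, since 4-methylpiperidin-1-yl differs from pyrrolidin-1-yl in both, and plain piperidin-1-yl would stand between the two. They also leave open whether a ring with a second hetero atom, such as morpholin-4-yl, would keep the step, and whether it would carry over to the core of compound 1.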